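A Chlorine Added to the Core of Compound 1

This account rests on a few compounds, and the source may have more. Where it says the series, first, only, none or still open, it means among the compounds named here.

Among the compounds with values here, compound 1 `O=C(Nc1ccc(Sc2nc3ccccc3s2)cc1)c1cc(Br)cc(Br)c1O` is the only member of this set with a number rather than a limit: in an ADME assay on HEK293 cells (Homo sapiens) for cytotoxicity, read by reporter gene assay and resazurin assay, with a stated time of 48 h (on this read-out lower numbers stand for higher toxicity in this test and higher numbers for lower toxicity in this test), compound 1 gives 66000 nM. Compound 2 `COc1ccc(Br)cc1C(=O)Nc1ccc(Sc2nc3ccccc3s2)cc1` in this assay gives > 100000 nM, which is a limit of the assay. Compound 3 `O=C(Nc1ccc(Sc2nc3ccccc3s2)cc1)c1cc(Br)cc(Br)c1` in this assay gives > 100000 nM, also a limit. The two measured steps, an at least 1.5-fold higher number from compound 1 to compound 2 (0.18 log units; that floor lies within the scatter) and an at least 1.5-fold higher number from compound 1 to compound 3 (0.18 log units; that floor lies within the scatter), both alter the ring on the carbonyl carbon, and both run up against (the limit of > 100000 nM in this assay, at which 2 of the 3 values shown sit). Within the data shown here, compound 4 `O=C(Nc1ccc(Sc2nc3ccccc3s2)c(Cl)c1)c1cc(Br)cc(Br)c1O` differs from compound 1 by chloro in place of hydrogen on an aromatic carbon, a change on the other ring, on which none of the measured steps bears. For compound 4 a step of no change at the digits printed from compound 1 to compound 4 (within the scatter) is therefore expected, none beyond the scatter. The estimate for compound 4 is 66000 nM, between 30000 nM and 150000 nM.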

Compound 4, half-maximal cytotoxic concentration: 76000 nM
Compound 4: middle estimate off by 1.2-fold (0.06 log units), on the low side; measured number inside the range.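

In this assay, the only change shown on this ring gives a 1.2-fold higher number from compound 1 to compound 4 (0.06 log units; within the scatter), so chloro in place of hydrogen on this aromatic carbon, ortho to a large group and meta to a large group, leaves the read-out unchanged within the scatter. Compound 4 also keeps a number, which compound 2 and compound 3 do not, so this ring can be read directly: the limit of > 100000 nM in this assay, at which 2 of the 4 values shown sit. Going by these compounds, whether an amine or a carboxylic acid on this carbon would also stay within the scatter remains open. So does whether chloro would behave alike without the hydroxy group.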